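Series notes: methanesulfonamido in place of cyano

The source may report more compounds than this note shows. Statements on the series, on what has been measured and on what is new or still open speak of the compounds shown alone.

In a functional assay on MC-38 cells (Mus musculus) for antiproliferative activity (a lower number here means a stronger inhibitor, a higher number a weaker inhibitor), compound 1 (`N#Cc1ccc(S(=O)(=O)Nc2cccc3cc[nH]c23)cc1`) gives 1.8 ug/mL and compound 2 (`N#Cc1ccc(S(=O)(=O)Nc2cccc3c(Cl)c[nH]c23)cc1`) gives 0.13 ug/mL. Within the data shown here, compound 2 therefore holds the lower of the two numbers available so far. Chloro in place of hydrogen on an aromatic carbon is the only measured step in the series: a 14-fold lower number from compound 1 to compound 2 (1.14 log units; beyond the scatter).

Compound 3 (`CS(=O)(=O)Nc1ccc(S(=O)(=O)Nc2cccc3c(Cl)c[nH]c23)cc1`) keeps that chloro and changes the other end of compound 2, with methanesulfonamido in place of cyano on an aromatic carbon, para to a large group: methanesulfonamido in place of cyano on an aromatic carbon.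

Among the measured compounds shown here, no measured step replaces the cyano group, so the large chloro step bears on this change only indirectly. It shows how far the number can move within the series, but not the direction of this exchange. The starting point for the estimate is compound 2 at 0.13 ug/mL, and this assay is expected to shift little, perhaps slightly towards a higher number. The estimated change is a 1.5-fold higher number from compound 2 to compound 3 (0.19 log units; within the scatter), which is not expected to be a large step. For compound 3 the expected value is 0.2 ug/mL, with an estimated range of 0.05 ug/mL to 0.8 ug/mL.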

Compound 3, half-maximal inhibitory concentration: 0.26 ug/mL
Estimate against measurement, compound 3: 1.3-fold (0.11 log units) below; low and high end bracket the measured number.
By their numbers in this assay, from the lowest: compounds 2 and 3 (each within the scatter of the next); then compound 1.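

Among these compounds, the earlier compounds showed a change at the chloro position only; this pair gives the first reading on the aromatic carbon para to a large group. In this assay methanesulfonamido in place of cyano gives a 2.0-fold higher number from compound 2 to compound 3 (0.30 log units; within the scatter) and so leaves compound 2 and compound 3 inseparable, even though the entering group has more heavy atoms and brings a hydrogen-bond donor that cyano lacks. With the chloro kept, this position therefore accepts both groups without a change in the number that can be read beyond the scatter, but nothing available here explains this result.

Among the compounds shown here, the single pair does not show whether the same exchange would hold without the chloro, or whether the cyano and methanesulfonamido groups are interchangeable in other settings. It also leaves open how an amine, a carboxylic acid or a longer chain in place of the methyl of methanesulfonamido would read on this aromatic carbon, and so how much of the position's apparent latitude extends beyond these two groups.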